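The compounds below may be only part of what the source reports. "The series", "measured", "known", "first", "only" and "open" are said of these compounds alone.

In a functional assay on WiDr cells (Homo sapiens) for inhibition, read by sulforhodamine B assay, with a stated time of 48 h (a higher number here means a weaker inhibitor of growth, a lower number a stronger inhibitor of growth), the three measured compounds are: compound 1 `COC(=O)[C@@]1(C)CCC=C2[C@@H]1CC[C@@H](C)[C@]2(C)Cc1c(C)[nH]c2ccc(C)cc12` with 28000 nM; compound 2 `COC(=O)[C@@]1(C)CCC=C2[C@@H]1CC[C@@H](C)[C@]2(C)Cc1c(C)[nH]c2ccc(Br)cc12` with 15000 nM; compound 3 `COC(=O)[C@@]1(C)CC[C@@H]2C3=C1CC[C@@H](C)[C@]3(C)C[C@@H]1c3cc(C)ccc3N[C@H]21` with 32000 nM. Compound 4 `COC(=O)[C@@]1(C)CC[C@@H]2C3=C1CC[C@@H](C)[C@]3(C)C[C@@H]1c3cc(Br)ccc3N[C@H]21` has not yet been measured.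

Compound 1 and compound 2 differ in one place: bromo in place of methyl on an aromatic carbon. That change gave a 1.9-fold lower number from compound 1 to compound 2 (0.27 log units; within the scatter). Compound 3 and compound 4 differ by the same kind of change, (bromo in place of methyl on an aromatic carbon). The two places are not the same word for word: in compound 1 the six-membered ring is part of a fused or bridged system of two rings, in compound 3 of five rings, so the change is of the same kind, not the same. The difference between the core of compound 1 and the core of compound 3 is not broken down here. Compound 3 has the highest number of the three; its gap to compound 1 lies within the scatter, its gap to compound 2 beyond it.

For compound 4 a step of a 1.8-fold lower number from compound 3 to compound 4 (0.25 log units; within the scatter) is expected, resting on compound 1 and compound 2, because a 1.9-fold lower number from compound 1 to compound 2 (0.27 log units; within the scatter). Compound 4 is estimated at 18000 nM, expected to fall between 8000 nM and 40000 nM.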

Compound 4, concentration for 50% growth inhibition: 55000 nM
Estimate against measurement, compound 4: 3.1-fold (0.49 log units) below; measured number outside the range, above it.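

In this assay, bromo in place of methyl on an aromatic carbon gave a 1.7-fold higher number from compound 3 to compound 4 (0.24 log units; within the scatter). Set beside the earlier step, the same change did not carry over from one core to the other: the same change on two cores in this assay, a 1.9-fold lower number (0.27 log units; within the scatter) from compound 1 to compound 2 and a 1.7-fold higher number (0.24 log units; within the scatter) from compound 3 to compound 4, 3.2-fold (0.51 log units) apart, beyond the scatter of two such steps. Among the compounds shown here, each step on its own lies within the scatter, so the result shows only that the step seen on the core of compound 1 cannot be transferred as a fixed amount to the core of compound 3; with a single pair on each core, it does not show which feature of the two cores lies behind the gap, or whether the gap is general for this series.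

The compounds shown leave open how other groups at this place, such as chloro, methoxy or a plain hydrogen, would behave on each core. They also leave open whether a gap between the two cores would appear again with an amine or a carboxylic acid in place of the methyl ester both cores carry.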